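This account rests on a few compounds, and the source may have more. Where it says the series, first, only, none or still open, it means among the compounds named here.

Measured so far:
Compound 1, `C/C(=N\NC(=O)COc1cccc2ccccc12)c1ccc(C#N)cc1Br`, gives 12.7 ug/mL in an ADME assay on HEL cells (Homo sapiens) for cytotoxicity; a higher number here means that more compound is tolerated, a lower number that less compound is tolerated.
Compound 2, `O=C(COc1cccc2ccccc12)N/N=C/c1ccccc1Br`, gives 100 ug/mL.
Compound 3, `C/C(=N\NC(=O)COc1cccc2ccccc12)c1ccccc1O`, gives 4 ug/mL.

Compound 2 stands highest of the three, so it is the one the cells tolerate best; compound 1 sits beyond the scatter below it, and compound 3 further below still. Compound 4, `O=C(COc1cccc2ccccc12)N/N=C/c1ccc(F)cc1`, has not yet been measured. It differs from compound 2 in one place: 4-fluorophenyl in place of 2-bromophenyl on a carbon with a double bond to nitrogen. Among the measured compounds shown here, only one measured step speaks to a swap of the ring on the carbon with a double bond to nitrogen, and that is a 3.2-fold lower number from compound 1 to compound 3 (0.50 log units; beyond the scatter), a modest fall. For the measured compounds named here, no measured pair exchanges a 2-bromophenyl for a 4-fluorophenyl, so the direction for compound 4 rests on that single step alone. Because a 3.2-fold lower number from compound 1 to compound 3 (0.50 log units; beyond the scatter) lowered the number only modestly, a step of similar or smaller size downward, or none beyond the scatter, is expected here as a 2.0-fold lower number from compound 2 to compound 4 (0.30 log units; within the scatter). Compound 4 is therefore estimated at 50 ug/mL, within a range from 15 ug/mL to 100 ug/mL.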

Compound 4, half-maximal cytotoxic concentration: 71.6 ug/mL
For compound 4 the middle estimate is 1.4-fold (0.16 log units) below the measured one; low and high end bracket the measured number.
By their numbers in this assay, from the lowest: compound 3; then compound 1; then compounds 4 and 2 (each within the scatter of the next).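

In this assay, the exchange of one halogen-bearing phenyl group for another gives a 1.4-fold lower number from compound 2 to compound 4 (0.15 log units; within the scatter), so the two compounds cannot be told apart. The only earlier step at this place, a 3.2-fold lower number from compound 1 to compound 3 (0.50 log units; beyond the scatter), lay beyond the scatter, so a new ring on a carbon with a double bond to nitrogen does not always move the number; here the 4-fluorophenyl group keeps compound 4 with compound 2 among the best-tolerated compounds shown. No measurement at hand explains why this swap leaves the two compounds alike.

The halogen and its place on the ring both differ between the two groups, so these compounds cannot separate one from the other. From the compounds shown here alone, how a phenyl ring carrying an amine or a carboxylic acid would fare at this place also remains open.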